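The source may report more compounds than this note shows. Statements on the series, on what has been measured and on what is new or still open speak of the compounds shown alone.

Measured in a functional assay on A549 cells (Homo sapiens) for antiproliferative activity, read by MTT assay, with a stated time of 48 h; on this read-out lower numbers stand for stronger inhibition and higher numbers for weaker inhibition:
- Compound 1 `Cc1ccc(Nc2ccc3c(c2)C(O)(CCC(C)C)C(=O)N3)cc1`: 12500 nM
- Compound 2 `CCCCC1(O)C(=O)Nc2ccc(Nc3ccc(F)cc3)cc21`: 6500 nM
- Compound 3 `CCCCCC1(O)C(=O)Nc2ccc(Nc3ccc(F)cc3)cc21`: 5900 nM

In this assay compound 3 gives 5900 nM. This lies within the scatter of compound 2, while the higher number of compound 1 lies beyond the scatter from compound 3.

Compound 4 `CC(C)CCC1(O)C(=O)Nc2ccc(Nc3ccc(F)cc3)cc21` is the next to be measured. It differs from compound 3 as follows: isopropyl in place of propyl on a saturated chain carbon, two bonds along the chain from a saturated ring carbon. In words, this is isopropyl in place of propyl on a saturated chain carbon, two bonds along the chain from a saturated ring carbon.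

Going by the values given here, the one measured step that bears on this change is a 1.1-fold lower number from compound 2 to compound 3 (0.04 log units; within the scatter), and it stays within the scatter. Among the compounds with values here, compound 1 also carries an isopentyl chain, but it differs from compound 4 elsewhere too, so no measured step isolates the branching. No step beyond the scatter is therefore expected in this assay.

The expected step is a 1.1-fold higher number from compound 3 to compound 4 (0.04 log units; within the scatter).

For compound 4 the estimate is 6500 nM, with an expected range of 3500 nM to 12000 nM.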

Compound 4, half-maximal inhibitory concentration: 5700 nM
Estimate against measurement, compound 4: 1.1-fold (0.06 log units) above; low and high end bracket the measured number.
By their numbers in this assay, from the lowest: compounds 4, 3, 2 and 1 (each within the scatter of the next, the first and the last beyond it).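

In this assay, branching the chain, isopropyl in place of propyl on a saturated chain carbon, two bonds along the chain from a saturated ring carbon, leaves the number within the scatter (a 1.0-fold lower number from compound 3 to compound 4 (0.01 log units; within the scatter)), and the step with the shorter chain is also within the scatter (a 1.1-fold lower number from compound 2 to compound 4 (0.06 log units; within the scatter)), so butyl, pentyl and isopentyl cannot be told apart here. Going by these compounds alone, compound 4 also gives the first comparison that isolates fluoro in place of methyl on an aromatic carbon, with the isopentyl chain held constant, and this modest step lies beyond the scatter (a 2.2-fold lower number from compound 1 to compound 4 (0.34 log units; beyond the scatter)). Nothing available explains these numbers.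

As far as these compounds go, it remains open whether a longer chain, or a chain ending in an amine or a carboxylic acid, would stay within the scatter at this position. From the compounds shown here alone, it is equally open how chloro or methoxy would compare with fluoro on that aromatic carbon.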